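The source may hold more compounds than are shown below. What is called first, only, known or untested is meant among the compounds shown, and "the series" means these compounds.

Compound 1 `Cc1ccc(Cn2c(O)nc3c(N)ncnc32)cc1`: in a functional assay (spleen, spleen) for activation, with Mus musculus as the target (on this read-out lower numbers stand for an effect already at smaller amounts and higher numbers for an effect only at larger amounts of compound), compound 1 gives 10 uM.
Compound 2 `CCOc1nc(N)c2nc(O)n(Cc3ccccc3)c2n1`: in this assay compound 2 gives 0.1 uM.
Compound 3 `Nc1ncnc2c1nc(I)n2Cc1ccccc1`: in this assay compound 3 reaches only > 10 uM, which is a limit of the assay and not a number (the limit of > 10 uM in this assay, at which 1 of the 3 values shown sits).

Of the two actual numbers, compound 2 has the lower one; compound 1 sits far above it, a gap well beyond the usual scatter. Compound 4 `CCCCCSc1nc(N)c2nc(O)n(Cc3ccccc3)c2n1` differs from compound 2 in one place: pentylsulfanyl in place of ethoxy on an aromatic carbon. Within the data shown here, no measured pair isolates a change of this kind, so the expectation rests on compound 2 alone. A modest shift toward a larger effective concentration is expected, a 3.0-fold higher number from compound 2 to compound 4 (0.48 log units; beyond the scatter), not far beyond the scatter. Compound 4 is therefore estimated at 0.3 uM, with a likely range from 0.03 uM to 3 uM.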

Compound 4, minimum effective concentration: 10 uM
The estimate for compound 4 lay 33-fold (1.52 log units) below the measured number; measured number above the stated range.
By their numbers in this assay, from the lowest: compound 2; then compounds 1 and 4 (each within the scatter of the next).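

In this assay, pentylsulfanyl in place of ethoxy on the aromatic carbon between two ring nitrogen atoms gives a 100-fold higher number from compound 2 to compound 4 (2.00 log units; beyond the scatter), so what this position carries matters greatly. The change alters both the linking atom and the chain length, and this single pair cannot separate the two. The upper end of the read-out is close here: the limit of > 10 uM in this assay, at which 1 of the 4 values shown sits.

A pentyloxy chain or a shorter ethylsulfanyl chain would help show which part of the change matters. On these data alone, how an amine at this position would compare also remains open.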